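From Naphthalen-1-yl to 4-(Trifluoromethyl)phenyl at an Assay Limit

This account rests on a few compounds, and the source may have more. Where it says the series, first, only, none or still open, it means among the compounds named here.

Compound 1 `O=S(=O)(Oc1ccccc1)[C@H]1C[C@H]2O[C@@H]1C(c1ccc(O)cc1)=C2c1ccc(O)cc1` gives > 100000 nM in an ADME assay on Vero cells (Chlorocebus sabaeus) for inhibition, read by MTT assay, with a stated time of 72 h (a higher number here means a weaker inhibitor, a lower number a stronger inhibitor), as a limit and not as a number. Compound 2 `O=C(O)CCCCCCC(=O)Nc1ccc(C2=C(c3ccc(O)cc3)C3CC(S(=O)(=O)Oc4cccc5ccccc45)C2O3)cc1` gives > 100000 nM as a limit as well. Compound 3 `COc1ccccc1OS(=O)(=O)C1CC2OC1C(c1ccc(NC(=O)CCCCCCC(=O)NO)cc1)=C2c1ccc(O)cc1` also gives > 100000 nM as a limit. Compound 2 therefore has no measured number of its own and stands with the others at the limit of > 100000 nM in this assay, at which 3 of the 3 values shown sit, in this assay without any order among them.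

The next compound to be tested is compound 4 `O=C(O)CCCCCCC(=O)Nc1ccc(C2=C(c3ccc(O)cc3)C3CC(S(=O)(=O)Oc4ccc(C(F)(F)F)cc4)C2O3)cc1` which carries 4-(trifluoromethyl)phenyl in place of naphthalen-1-yl on an oxygen whose other neighbour is the sulfonyl sulfur. This is the change 4-(trifluoromethyl)phenyl in place of naphthalen-1-yl on an oxygen with the rest of compound 2 left as it is.

With compound 2 at > 100000 nM as a limit, no step beyond the scatter is expected in this assay in either direction. The expected step of a number no higher from compound 2 to compound 4 (the limit leaves the size open) is accordingly estimated as small. For compound 4 the estimate is 100000 nM with an expected range from 50000 nM to 200000 nM when it is measured.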

Compound 4, half-maximal inhibitory concentration: > 100000 nM
Compound 4 was reported as a limit; the forecaster's own chance of this, stated with the estimate: 85%; the middle value lies on the limit itself.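

In this assay, compound 2 and compound 4 are both reported as a limit and not as a number, and no step can be read between them. The compounds shown leave open whether exchanging naphthalen-1-yl for 4-(trifluoromethyl)phenyl changes the value in this assay, and how the four compounds would order among themselves.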